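Removing an Aromatic Bromo Substituent: Expected Cytotoxicity

The compounds below may be only part of what the source reports. "The series", "measured", "known", "first", "only" and "open" are said of these compounds alone.

Measured compounds:
compound 1, `Brc1cccc(/N=N/N2CCCCC2)c1`: > 100000 nM
compound 2, `FC(F)(F)c1cccc(N(C[C@@H]2CCCN3CCCC[C@H]23)/N=N/c2ccccc2)c1`: 22000 nM
compound 3, `Clc1cccc(/N=N/N2CCCC2)c1`: > 100000 nM

In an ADME assay on MDBK cells (Bos taurus) for cytotoxicity, read by MTT assay, with a stated time of 96 h (a lower number here means that less compound is tolerated, a higher number that more compound is tolerated), compound 1 gives > 100000 nM, which is a limit of the assay and not a number. Compound 3 likewise sits at a limit, > 100000 nM. Only compound 2 gives a number, 22000 nM. Compound 1 therefore stands at the limit of > 100000 nM in this assay, at which 2 of the 3 values shown sit.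

Compound 4, `c1ccc(/N=N/N2CCCCC2)cc1`, differs from compound 1 by hydrogen in place of bromo on an aromatic carbon. No step between measured compounds is shown for such a change, so the expectation rests on compound 1 alone. In this assay the expected step is none beyond the usual scatter. Compound 4 is therefore expected near 100000 nM, within a range of 40000 nM to 300000 nM, most likely again as a limit. That estimate means an expected step of a number no higher from compound 1 to compound 4 (the limit leaves the size open).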

Compound 4, half-maximal cytotoxic concentration: > 100000 nM
Compound 4 was reported as a limit; the forecaster's own chance of this, stated with the estimate: 70%; the middle value sits exactly at the limit.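

In this assay, compound 1 and compound 4 both stand at a limit, and the step between them cannot be read. The compounds shown leave open whether hydrogen in place of bromo changes cytotoxicity at all.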